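The source may report more compounds than this note shows. Statements on the series, on what has been measured and on what is new or still open speak of the compounds shown alone.

Series notes. Compound 1 `COc1ccc(Nc2cc(C)oc(=O)c2)cc1` carries a methyl on the shared core. In a functional assay on KB cells (Homo sapiens) for cytotoxicity, read by MTT assay, with a stated time of 72 h (a lower number here means that less compound is needed, a higher number that more compound is needed for the effect), compound 1 gives only a limit, > 30 uM. Compound 2 `COc1ccc(Nc2cc(C3CCCCC3)oc(=O)c2)cc1` carries a cyclohexyl at the same place, and in this assay compound 2 gives 8.32 uM. Compound 3 `COc1ccc(Nc2cc(-c3ccccc3)oc(=O)c2)cc1` carries a phenyl there, and in this assay compound 3 gives 0.16 uM, the lowest of the two numbers shown; the nearest is compound 2, and that step reads a 52-fold lower number from compound 2 to compound 3 (1.72 log units; beyond the scatter). The steps away from the methyl read an at least 3.6-fold lower number from compound 1 to compound 2 (0.55 log units; beyond the scatter) and an at least 180-fold lower number from compound 1 to compound 3 (2.27 log units; beyond the scatter). Compound 4 `COc1ccc(Nc2cc(-c3ccco3)oc(=O)c2)cc1` is not yet measured; it differs from compound 3 by furan-2-yl in place of phenyl on an aromatic carbon. Within the data shown here, both measured steps into compound 3 concern the arrival of a phenyl in place of a methyl or a cyclohexyl, and both were large; the step to compound 4 keeps an aromatic ring and exchanges it for a five-membered aromatic ring with one hetero atom, a change for which no measured step exists in this set. A small step, if any beyond the scatter, is therefore expected in this assay, with the risk lying toward a higher number. The step expected is a 2.5-fold higher number from compound 3 to compound 4 (0.40 log units; beyond the scatter). Compound 4 is estimated at 0.4 uM, between 0.1 uM and 1.6 uM.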

Compound 4, concentration for half-maximal effect: 2.66 uM
Estimate against measurement, compound 4: 6.7-fold (0.82 log units) below; the whole stated range lies below it.
By their numbers in this assay, from the lowest: compound 3; then compound 4; then compound 2. At a limit, above all of these: compound 1.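

Keeping an aromatic ring at this place, next to the ring oxygen, is not enough to hold the number of the phenyl in this assay: a 17-fold higher number from compound 3 to compound 4 (1.22 log units; beyond the scatter), so the low value of compound 3 belongs to the phenyl and is not shared by the furan-2-yl among the aromatic rings shown. The furan-2-yl nevertheless keeps an advantage over the cyclohexyl, with a 3.1-fold lower number from compound 2 to compound 4 (0.50 log units; beyond the scatter), which gives phenyl, furan-2-yl and cyclohexyl as the order at this place, and the step from cyclohexyl to furan-2-yl is clearly the smaller of the two steps into an aromatic ring from cyclohexyl. Compound 1 stands at a limit, so an at least 11-fold lower number from compound 1 to compound 4 (1.05 log units; beyond the scatter) marks only a bound on the size of that step: the limit of > 30 uM in this assay, at which 1 of the 4 values shown sits.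

The exchange of phenyl for furan-2-yl changes both the ring size and the presence of a ring oxygen, and the compounds shown cannot separate these two changes; a thiophen-2-yl or a pyridin-3-yl at this place would bear on that. Also open, on these data alone, is how a phenyl carrying a fluorine, a methoxy or an amine would read in this assay.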